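Diallylamino replaces methyl(propyl)amino on a fused triazine core

The source may report more compounds than this note shows. Statements on the series, on what has been measured and on what is new or still open speak of the compounds shown alone.

Of the compounds shown here, two sharing a fused bicyclic core have been measured in an assay on cell membranes for displacement of a labelled ligand from corticotropin-releasing factor receptor 1 (Rattus norvegicus); a lower number here means a stronger inhibitor, a higher number a weaker inhibitor. Compound 1 `CCC(CC)Nc1nc(C)nc2c(-c3cc(F)c(OC)cc3Cl)c(C)nn12` gives 1 nM in this assay. Compound 2 `CCCN(C)c1nc(C)nc2c(-c3c(C)cc(OC)cc3OC)c(C)nn12` gives 6.48 nM in this assay, the higher of the two numbers, standing a wide and clearly resolved gap away from compound 1; the two differ in several places at once, so no single change accounts for that gap.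

Compound 3 `C=CCN(CC=C)c1nc(C)nc2c(-c3c(C)cc(OC)cc3OC)c(C)nn12` is the next compound, not yet measured. It differs from compound 2 in one place: diallylamino in place of methyl(propyl)amino on an aromatic carbon. No measured pair isolates this exchange, so the size of its effect is unknown from the data shown. Given that compound 2 already gives 6.48 nM in this assay, the step from compound 2 to compound 3 is expected to be small, a 1.3-fold lower number from compound 2 to compound 3 (0.11 log units; within the scatter), not clearly beyond the scatter in either direction. Compound 3 is accordingly estimated at 5 nM in this assay, with a range from 1.5 nM to 20 nM.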

Compound 3, half-maximal inhibitory concentration: 1 nM
Estimate against measurement, compound 3: 5.0-fold (0.70 log units) above; the measured number lies below the stated range.
By their numbers in this assay, from the lowest: compounds 1 and 3 (each within the scatter of the next); then compound 2.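

In this assay, the exchange of methyl(propyl)amino for diallylamino gives a 6.5-fold lower number from compound 2 to compound 3 (0.81 log units; beyond the scatter), so this aromatic carbon, between two ring nitrogen atoms, is a position where the amine substituent affects the result. Among the compounds shown here, this is the first comparison in which a single place changes: the substituted aryl group and the rest of the shared core stay the same, which ties the gap to this exchange alone. The data shown offer no explanation for the gain.

The compounds shown leave open whether the double bonds matter, since dipropylamino, the saturated counterpart of diallylamino, does not appear among them. They also do not show how a cyclic amine such as morpholine would compare at this position, or whether diallylamino has the same effect alongside the aryl group of compound 1.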